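The source may report more compounds than this note shows. Statements on the series, on what has been measured and on what is new or still open speak of the compounds shown alone.

Working notes on the series. Three compounds have been run in a functional assay on HepG2 cells (Homo sapiens) for inhibition, read by MTT assay, with a stated time of 72 h; on this read-out higher numbers stand for weaker inhibition and lower numbers for stronger inhibition. Compound 1 `CC(C)n1ncc2c(C(=O)Nc3cccnc3)cccc21` carries pyridin-3-yl on the amide nitrogen. In this assay compound 1 gives > 40000 nM, which is a limit of the assay and not a number. Compound 2 `CC(C)n1ncc2c(C(=O)NCc3ccccc3)cccc21` has benzyl in place of pyridin-3-yl on that nitrogen. In this assay compound 2 gives > 40000 nM, again a limit. The step that the two limits leave unreadable from compound 1 to compound 2 is left unreadable by the two limits.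

Compound 3 `Cc1ccc(-n2cc(CNC(=O)c3cccc4c3cnn4C(C)C)nn2)c(C)c1` is the triazole-bearing member. In this assay compound 3 gives > 40000 nM, a limit. Where compound 3 stands is therefore only a limit, like the other two shown: the limit of > 40000 nM in this assay, at which 3 of the 3 values shown sit.

Compound 4 `Cc1cccc(-n2cc(CNC(=O)c3cccc4c3cnn4C(C)C)nn2)c1` has not been measured. It differs from compound 3 by 3-methylphenyl in place of 2,4-dimethylphenyl on an aromatic nitrogen. Among the measured compounds shown here, no measured step touches this place; the only step, the one from compound 1 to compound 2, sits on the amide nitrogen and is unreadable in any case. The expectation for compound 4 thus rests on (the limit of > 40000 nM in this assay, at which 3 of the 3 values shown sit), and on the closeness of the two substituted phenyl groups. Compound 4 is expected to give 60000 nM in this assay, with a range of 20000 nM to 200000 nM. The step that the limit leaves unreadable from compound 3 to compound 4 is expected to be none beyond the scatter, most likely ending in a limit again.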

Compound 4, half-maximal inhibitory concentration: > 40000 nM
Compound 4 gave a limit, no number (the forecaster's own chance of this, stated with the estimate: 80%); the middle value lies beyond the limit too.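

No new step can be read: compound 3 and compound 4 both sit at a limit of this assay and not at a number, so the change from 2,4-dimethylphenyl to 3-methylphenyl has no readable size. The compounds shown leave open whether any change to this series gives a measurable value in this assay, since all of them sit at the same limit: the limit of > 40000 nM in this assay, at which 4 of the 4 values shown sit.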